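The source may report more compounds than this note shows. Statements on the series, on what has been measured and on what is new or still open speak of the compounds shown alone.

Going by the values given here, compound 1 `CN1CCN(c2ccc(Nc3ncc4nc(Nc5ccc(F)cc5)n([C@H]5CCCN(S(=O)(=O)C6CC6)C5)c4n3)cc2)CC1` is one of three compounds measured in a functional assay on HCC827 cells (Homo sapiens) for antiproliferative activity, read by MTT assay, with a stated time of 72 h (a lower number here means a stronger inhibitor, a higher number a weaker inhibitor), where compound 1 gives 8.6 nM. It stands second highest of the three numbers. Compound 3 `CN1CCN(c2ccc(Nc3ncc4nc(Nc5ccccc5)n([C@@H]5CCN(S(=O)(=O)C6CC6)C5)c4n3)cc2)CC1` gives the lowest number, 0.88 nM, while compound 2 `CC(=O)N1CC[C@H](n2c(Nc3ccccc3)nc3cnc(Nc4ccc(N5CCN(C)CC5)cc4)nc32)C1` gives the highest, 260 nM, so compound 1 lies between them and beyond the scatter from each.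

Among the compounds with values here, the single step among the measured compounds that changes only one place is a 300-fold lower number from compound 2 to compound 3 (2.47 log units; beyond the scatter), in which 1-(cyclopropylsulfonyl)pyrrolidin-3-yl replaces 1-acetylpyrrolidin-3-yl on an aromatic nitrogen.

Compound 4 `CN1CCN(c2ccc(Nc3ncc4nc(Nc5ccc(F)cc5)n([C@H]5CCCN(C(=O)CO)C5)c4n3)cc2)CC1` has not yet been measured in this assay. It differs from compound 1 in one place: (hydroxymethyl)carbonyl in place of cyclopropylsulfonyl on an amine nitrogen in a ring. The group on the ring nitrogen thus moves from a sulfonyl to a carbonyl, the reverse of the direction taken in the step from compound 2 to compound 3, though here on a piperidine ring and with a (hydroxymethyl)carbonyl rather than an acetyl. Since that measured step was large, a large rise in number is expected for compound 4, estimated as a 47-fold higher number from compound 1 to compound 4 (1.67 log units; beyond the scatter), though the size carries uncertainty as the ring and the carbonyl group both differ from the measured pair. Compound 4 is therefore expected to give about 400 nM in this assay, within a range of 60 nM to 3000 nM.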

Compound 4, half-maximal inhibitory concentration: 1.8 nM
For compound 4 the middle estimate is 220-fold (2.35 log units) above the measured one, outside the stated range (below it).
By their numbers in this assay, from the lowest: compound 3; then compound 4; then compound 1; then compound 2.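

On the piperidine ring, the sulfonyl group proves unnecessary for a low number in this assay: putting (hydroxymethyl)carbonyl in place of cyclopropylsulfonyl on the ring amine nitrogen gives a 4.8-fold lower number from compound 1 to compound 4 (0.68 log units; beyond the scatter). The direction is opposite to that seen with the pyrrolidine compounds, where the change from a carbonyl group to a sulfonyl group gave a 300-fold lower number from compound 2 to compound 3 (2.47 log units; beyond the scatter), so the earlier step does not carry over as a general preference for sulfonyl over carbonyl, although the two steps also differ in the ring and in the carbonyl group involved. Nothing in the available data accounts for this reversal.

Going by these compounds, it remains open whether the hydroxymethyl part of the new group matters, or whether an acetyl or a methoxyacetyl group on this piperidine nitrogen would give a number close to that of compound 4. On these data alone, it is also open whether the ring decides the direction of the change, which (hydroxymethyl)carbonyl on the pyrrolidine nitrogen of compound 3 or an aminoacetyl group at either ring could begin to settle.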